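The compounds below may be only part of what the source reports. "The series", "measured", "known", "first", "only" and "open" are said of these compounds alone.

In a functional assay on HepG2 cells (Homo sapiens) for inhibition, read by MTT assay, with a stated time of 48 h (a higher number here means a weaker inhibitor, a lower number a stronger inhibitor), compound 1 `N#Cc1c(-c2ccccc2)nc2c(c(-c3ccccc3)nn2-c2ccccc2)c1-c1ccc(N2CCCCC2)cc1` gives 30900 nM and compound 2 `O=C(C=CNc1cc(-c2ccccc2)nn1-c1ccccc1)c1ccc(Br)cc1` gives 8810 nM while compound 3 `Clc1ccc(-c2ccnc3c2c(-c2ccccc2)nn3-c2ccccc2)cc1` gives 61100 nM on the same read-out. Compound 3 lies within the scatter of compound 1 and has a higher number than compound 2, a gap beyond the scatter. Compound 4 `COc1ccc(-c2ccnc3c2c(-c2ccccc2)nn3-c2ccccc2)cc1` differs from compound 3 in one place: methoxy in place of chloro on an aromatic carbon with methoxy in place of chloro on an aromatic carbon, para to a large group. For the measured compounds named here, no measured pair shows this change, so the expectation stays cautious. The expected step is a 1.5-fold lower number from compound 3 to compound 4 (0.18 log units; within the scatter) toward a lower number, within the scatter. For compound 4 the estimated value is 40000 nM with a range of 15000 nM to 90000 nM around it.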

Compound 4, half-maximal inhibitory concentration: 6590 nM
The estimate for compound 4 lay 6.1-fold (0.78 log units) above the measured number; measured number outside the range, below it.
By their numbers in this assay, from the lowest: compounds 4 and 2 (each within the scatter of the next); then compounds 1 and 3 (each within the scatter of the next).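

In this assay methoxy in place of chloro, on an aromatic carbon para to a large group, gives a 9.3-fold lower number from compound 3 to compound 4 (0.97 log units; beyond the scatter) and a step beyond the scatter. For the compounds shown here, this is the first single-place change, so it shows that activity at this position depends on which group is present, at least for 4-chlorophenyl to 4-methoxyphenyl.

As far as these compounds go, whether an amine or a longer alkoxy chain on the same carbon would continue this step remains open. No measured evidence here accounts for the step.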